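The source may report more compounds than this note shows. Statements on the series, on what has been measured and on what is new or still open speak of the compounds shown alone.

Of the compounds shown here, three sharing one core have been tested in an ADME assay on HEK293 cells (Homo sapiens) for cytotoxicity, read by MTT assay; on this read-out higher numbers stand for weaker inhibition and lower numbers for stronger inhibition. Compound 1 `Cc1cccc(/C=C/C(=O)c2c(O)cc(C)oc2=O)c1` gives 100000 nM in this assay. Compound 2 `Cc1cc(O)c(C(=O)/C=C/c2ccc(C(F)(F)F)cc2)c(=O)o1` gives 100000 nM. Compound 3 `COc1cc(OC)c(OC)cc1/C=C/C(=O)c1c(O)cc(C)oc1=O` gives 100000 nM, level with compounds 1 and 2 at the digits shown and within the scatter of both. Compound 4 `COc1ccc(OC)c(/C=C/C(=O)c2c(O)cc(C)oc2=O)c1` differs from compound 3 by a single change: hydrogen in place of methoxy on an aromatic carbon. Going by the values given here, no step between measured compounds has been quantified, so the size of this change on the read-out is open; the three measured values, all at one figure, give no sign that removing a methoxy from the aromatic carbon would move the number beyond the scatter in either direction. Compound 4 is therefore expected to give about 100000 nM in this assay, within a range of 50000 nM to 200000 nM, which means an expected step of no change at the digits printed from compound 3 to compound 4 (within the scatter).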

Compound 4, half-maximal inhibitory concentration: 100000 nM
Compound 4: middle estimate and measured number agree at the digits printed; the range from low to high includes it.
By their numbers in this assay, from the lowest: compounds 1, 2, 3 and 4 (each within the scatter of the next).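

Going by these compounds alone, replacing the methoxy with hydrogen on the aromatic carbon para to a large group gives no change at the digits printed from compound 3 to compound 4 (within the scatter) in this assay, the first step here that isolates a single change. At this position, then, the methoxy can be lost without the number leaving the scatter. Nothing measured here points to a cause for this result.

On these data alone, whether an amine, a carboxylic acid or a longer chain on this carbon would move the number remains open. So does the effect of removing either remaining methoxy from compound 4.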